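A few compounds are considered here, and "the series" means these few. Any claim that something is new, unique, unknown or untested is made for them only; others in the source may bear on it.

Compound 1 `CN(O)/C=C\C(=O)c1ccc([N+](=O)[O-])cc1` in an assay on RBL-1 cells for inhibition of Polyunsaturated fatty acid 5-lipoxygenase (Rattus norvegicus) (a lower number here means a stronger inhibitor, a higher number a weaker inhibitor), gives 1500 nM. Compound 2 `O=C(/C=C\N(O)Cc1ccc(-c2ccccc2)cc1)c1ccc(F)cc1` in this assay gives 3000 nM; the two numbers lie within the scatter of each other, so neither compound can be called the stronger inhibitor on these data. Compound 3 `O=C(/C=C\N(O)Cc1ccc(-c2ccccc2)cc1)c1ccco1` is not yet measured; it carries furan-2-yl in place of 4-fluorophenyl on a carbonyl carbon. Among the measured compounds shown here, no step between measured compounds touches this part of the shared core, so the change cannot be calibrated from the numbers in hand. The step of a 1.3-fold higher number from compound 2 to compound 3 (0.12 log units; within the scatter) is estimated to be small, not beyond the scatter. For compound 3 the estimate is 4000 nM, within 1500 nM to 12000 nM.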

Compound 3, half-maximal inhibitory concentration: 3100 nM
Compound 3: middle estimate off by 1.3-fold (0.11 log units), on the high side, and the stated range covers the measured number.
By their numbers in this assay, from the lowest: compounds 1, 2 and 3 (each within the scatter of the next, the first and the last beyond it).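

Furan-2-yl in place of 4-fluorophenyl on a carbonyl carbon gives a 1.0-fold higher number from compound 2 to compound 3 (0.01 log units; within the scatter) in this assay and is the first step that can be read at this position. In this pair, a five-membered aromatic ring with 1 hetero atom and a six-membered aromatic ring of carbon only cannot be told apart. No available evidence bears on this result.

Still open, from the compounds shown here alone, is whether an aromatic ring is needed on this carbonyl carbon at all. Cyclohexyl or methyl there would test that.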